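From compound 2 to compound 3 at the limit

A few compounds are considered here, and "the series" means these few. Any claim that something is new, unique, unknown or untested is made for them only; others in the source may bear on it.

In an ADME assay on BJ cells (Homo sapiens) for cytotoxicity, with a stated time of 72 h (on this read-out higher numbers stand for an effect only at larger amounts of compound and lower numbers for an effect already at smaller amounts), compound 1 `CCc1ccc(-c2nc3c(c(C)nn3-c3ccccc3)c(-c3ccccc3C)c2C#N)cc1` gives > 20000 nM as a limit and not a number. In this assay compound 2 `CCc1ccc(-c2nc3c(c(C)nn3-c3ccccc3)c(-c3ccccc3OC(F)(F)F)c2C#N)cc1` gives > 20000 nM as a limit too. Going by the values given here, the series so far stands at the limit of > 20000 nM in this assay, at which 2 of the 2 values shown sit, and compound 2 therefore has no number of its own. Among the compounds with values here, the one measured step is a step that the two limits leave unreadable from compound 1 to compound 2 and it offers no size to carry forward.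

Compound 3 `CCc1ccc(-c2nc3c(c(C)nn3-c3ccccc3)c(-c3cccc(O)c3)c2C#N)cc1` has 3-hydroxyphenyl in place of 2-(trifluoromethoxy)phenyl on an aromatic carbon, opposite the ring nitrogen 3-hydroxyphenyl in place of 2-(trifluoromethoxy)phenyl on an aromatic carbon and the core is unchanged. With no readable step to draw on, no step beyond the scatter is expected in this assay and no direction can be given with confidence. The expected step is a number no higher from compound 2 to compound 3 (the limit leaves the size open) as an estimate only. The estimate for compound 3 is 20000 nM with an expected range from 8000 nM to 40000 nM and another limit is the likeliest report.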

Compound 3, half-maximal effective concentration: > 20000 nM
Compound 3 ended at the assay's limit; the forecaster's own chance of this, stated with the estimate: 80%; the middle value lies on the limit itself.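

In this assay compound 3 gives > 20000 nM, a limit and not a number, so its steps from compound 1 and compound 2 cannot be read. The compounds shown leave open whether any substituent at this place on the shared core gives a measurable half-maximal effective concentration.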